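From pentan-3-yl to cyclopropyl on a shared core

The source may report more compounds than this note shows. Statements on the series, on what has been measured and on what is new or still open speak of the compounds shown alone.

In a physicochemical assay for solubility, in phosphate buffer, measured as kinetic solubility (on this read-out lower numbers stand for lower solubility and higher numbers for higher solubility), compound 1 (`CC(C)C(CC1C(=O)NC(=O)N1C)c1ccc(-c2ccc3cccc(F)c3c2)[nH]c1=O`) gives 33600 nM and compound 2 (`CC(C)[C@@H](c1ccc(-c2ccc3cccc(F)c3c2)[nH]c1=O)[C@@H]1OC(=O)NC1=O`) gives 27400 nM. Compound 3 (`CCC(CC)C(/C=C1\OC(=O)NC1=O)c1ccc(-c2ccc3cccc(F)c3c2)[nH]c1=O`) gives 33700 nM, within the scatter of both. Compound 4 (`O=C1NC(=O)/C(=C/C(c2ccc(-c3ccc4cccc(F)c4c3)[nH]c2=O)C2CC2)O1`) carries cyclopropyl in place of pentan-3-yl on a saturated chain carbon bound to an aromatic carbon and a double-bonded chain carbon. Among the compounds with values here, no measured pair isolates this change, so the evidence is thin. Compound 2 at 27400 nM and compound 3 at 33700 nM nevertheless agree despite their different structures, so no step beyond the scatter is expected in this assay. The expected change is a 1.1-fold higher number from compound 3 to compound 4 (0.03 log units; within the scatter). For compound 4 the estimate is 36000 nM, with an expected range of 19000 nM to 65000 nM.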

Compound 4, solubility: 30800 nM
Compound 4: middle estimate off by 1.2-fold (0.07 log units), on the high side; the range from low to high includes it.
By their numbers in this assay, from the lowest: compounds 2, 4, 1 and 3 (each within the scatter of the next).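

In this assay, within the data shown here, the change of pentan-3-yl to cyclopropyl on a saturated chain carbon bound to an aromatic carbon and a double-bonded chain carbon gives the first step that isolates this position, a 1.1-fold lower number from compound 3 to compound 4 (0.04 log units; within the scatter), on the shared core. At this position, the read-out therefore does not separate the open pentan-3-yl from the cyclopropyl ring.

From the compounds shown here alone, whether an amine or a carboxylic acid in the same place would also stay within the scatter remains open. Nothing shown explains this result.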